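The source may report more compounds than this note shows. Statements on the series, on what has been measured and on what is new or still open speak of the compounds shown alone.

Within the data shown here, in a functional assay on RS4-11 cells (Homo sapiens) for inhibition, read by CCK-8 assay, with a stated time of 48 h, tested at 20 uM (a higher number here means more inhibition of growth at the concentration tested, a lower number less inhibition of growth), compound 2 `Cc1ccc(S(=O)(=O)Oc2ccccc2/C=C(\C#N)C(=O)Nc2nnc(Cc3ccccc3)s2)cc1` gives 69%, the higher of the two numbers available so far. Compound 1 `N#C/C(=C\c1ccccc1OS(=O)(=O)c1ccc([N+](=O)[O-])cc1)C(=O)Nc1nnc(Cc2cccc3ccccc23)s1` gives 58%, and this gap lies beyond the usual scatter. The next compound to be read is compound 3 `N#C/C(=C\c1ccccc1OS(=O)(=O)c1ccc([N+](=O)[O-])cc1)C(=O)Nc1nnc(Cc2ccccc2)s1`, which has nitro in place of methyl on an aromatic carbon of compound 2 (nitro in place of methyl on an aromatic carbon). The change turns 4-methylphenyl into 4-nitrophenyl. Among the measured compounds shown here, no measured pair shows this change on its own, so the data offer only a weak guide, namely that compound 1 at 58% stands lower than compound 2. A small downward move in this assay is therefore expected, probably no larger than the scatter. The estimated step of a number 6 percentage points lower from compound 2 to compound 3 (within the scatter) reflects this cautious expectation. For compound 3 the expected value is 63%, with an estimated range from 48% to 78%.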

Compound 3, percent growth inhibition at one concentration: 57%
For compound 3 the middle estimate is 6 percentage points above the measured one, within the range that was stated.
By their numbers in this assay, from the lowest: compounds 3 and 1 (each within the scatter of the next); then compound 2.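

In this assay, among these compounds, nitro in place of methyl, para to a large group, gives a number 12 percentage points lower from compound 2 to compound 3 (beyond the scatter) and so provides the first direct reading of this change, showing that the position is sensitive to this exchange. With 4-nitrophenyl held constant, phenyl in place of naphthalen-1-yl gives a number 1 percentage points lower from compound 1 to compound 3 (within the scatter) and so does not separate these two groups in this setting. The information available gives no explanation for either step.

The compounds shown leave open how an amine or a methoxy group would read at the position that carries methyl or nitro. They also leave open whether phenyl and naphthalen-1-yl would stay within the scatter of each other alongside 4-methylphenyl.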